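Half-life notes: replacing 1,1-difluoroethyl with a thiazolyl group

A few compounds are considered here, and "the series" means these few. Any claim that something is new, unique, unknown or untested is made for them only; others in the source may bear on it.

Measured in an ADME assay on the whole organism (strain 129/SvEvBrd x C57BL/6) for metabolic stability, with Mus musculus as the target (on this read-out higher numbers stand for a longer-lived compound and lower numbers for a shorter-lived compound), so far:
- compound 1 `CC(O)c1nc([C@@H](O)[C@H](O)[C@H](O)CO)c[nH]1` gives 4.4 h here
- compound 2 `CC(F)(F)c1nc([C@@H](O)[C@H](O)[C@H](O)CO)c[nH]1` gives 1 h here

Among the measured compounds shown here, compound 2 at 1 h holds the lower of the two numbers, and compound 1 at 4.4 h is its only neighbour. The next change puts 2-methyl-1,3-thiazol-4-yl in place of 1,1-difluoroethyl on an aromatic carbon, giving compound 3 `Cc1nc(-c2nc([C@@H](O)[C@H](O)[C@H](O)CO)c[nH]2)cs1` (2-methyl-1,3-thiazol-4-yl in place of 1,1-difluoroethyl on an aromatic carbon). For the measured compounds named here, only one measured step bears on this: a 4.4-fold lower number from compound 1 to compound 2 (0.64 log units; beyond the scatter) is modest and beyond the scatter. Going by the values given here, it involves a different group pair, and no measured compound carries a ring at this place, so the guidance is weak. In this assay a step no larger than that one is expected, more likely upward since compound 2 at 1 h sits at the low end. The estimate amounts to a 1.8-fold higher number from compound 2 to compound 3 (0.26 log units; within the scatter) as the expected step. Compound 3 is estimated at 1.8 h with an expected range from 0.6 h to 5 h in this series.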

Compound 3, half-life: 2.1 h
For compound 3 the middle estimate is 1.2-fold (0.07 log units) below the measured one; the measured number falls inside the stated range.
By their numbers in this assay, from the lowest: compound 2; then compound 3; then compound 1.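

In this assay, the position on the aromatic carbon between two ring nitrogen atoms now also has a ring-bearing substituent: 2-methyl-1,3-thiazol-4-yl gives a 2.1-fold higher number from compound 2 to compound 3 (0.32 log units; beyond the scatter), while the same group set against 1-hydroxyethyl gives a 2.1-fold lower number from compound 1 to compound 3 (0.32 log units; beyond the scatter). The half-life at this place therefore responds to more than one kind of change, and the ring-bearing group lands between the two groups without a ring, rather than at either end of the three. Nothing measured here accounts for this order of the three groups.

On these data alone, what a thiazole without the methyl would give at this carbon remains open. So does whether a phenyl ring, a primary amine or a carboxylic acid would fall inside or outside the span set by these three compounds.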